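The source may report more compounds than this note shows. Statements on the series, on what has been measured and on what is new or still open speak of the compounds shown alone.

The account starts from compound 1 `C=C(Br)C(=O)Nc1cccc(-c2cn3nc(-c4ccc(F)cc4)sc3n2)c1`, which in a functional assay on CCRF-CEM cells (Homo sapiens) for inhibition, read by cell counting, with a stated time of 3 days (a lower number here means a stronger inhibitor, a higher number a weaker inhibitor), gives 830 nM, the lowest of the three numbers recorded so far. Compound 3 `C=C(Br)C(=O)Nc1cccc(-c2cn3c(-c4ccccc4)csc3n2)c1`, whose core differs in the arrangement of its fused rings, gives 2800 nM in this assay, a gap from compound 1 that lies beyond the scatter. Compound 2 `Nc1cccc(-c2cn3nc(Cc4ccc(Cl)cc4)sc3n2)c1`, which lacks the bromoacrylamide and carries a 4-chlorobenzyl group on its core, gives 42000 nM in this assay, far beyond the scatter from compound 1. The step now followed leads to compound 4 `C=C(Br)C(=O)Nc1cccc(-c2cn3nc(CCc4ccccc4)sc3n2)c1`, which keeps the bromoacrylamide of compound 1 and differs from it only in one place: phenethyl in place of 4-fluorophenyl on an aromatic carbon. Within the data shown here, no measured pair isolates this exchange. Compound 2, with a one-carbon link to its aryl group, is the weakest compound shown, but its amine in place of the acrylamide makes it no clean guide. Compound 4 is therefore expected to lose some potency, a step of a 2.4-fold higher number from compound 1 to compound 4 (0.38 log units; beyond the scatter), an estimated 2000 nM with a plausible range from 600 nM to 7000 nM.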

Compound 4, half-maximal inhibitory concentration: 4200 nM
Compound 4: the middle estimate sits 2.1-fold (0.32 log units) below what was measured, and the stated range covers the measured number.
By their numbers in this assay, from the lowest: compound 1; then compounds 3 and 4 (each within the scatter of the next); then compound 2.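

Among these compounds, with the bromoacrylamide held constant, the exchange of 4-fluorophenyl for phenethyl gives the first clean reading of this position: in this assay it is a 5.1-fold higher number from compound 1 to compound 4 (0.70 log units; beyond the scatter), a modest loss that still leaves compound 4 with a measurable value of 4200 nM in the same assay. The position thus accepts the phenethyl group, but the aryl group of compound 1 gives the lower number, and this single exchange removes the fluorine and introduces the chain at once. Nothing given here explains the size of this step.

The compounds shown leave open whether the loss follows the fluorine or the chain, which a plain phenyl or a 4-fluorophenethyl group on this core could separate. Also open, from the compounds shown here alone, is how a benzyl group, a longer chain or a terminal amine would read at this position.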